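Trimming the sulfonyl substituent in a stable acyl sulfonamide

This account rests on a few compounds, and the source may have more. Where it says the series, first, only, none or still open, it means among the compounds named here.

Compound 1 `CC(C)(C)NC(=O)NCCS(=O)(=O)NC(=O)c1ccc(Nc2nc(NC3(c4ccc(Cl)cc4)CC3)nc(OCC(F)(F)F)n2)cc1` gives 93% in an ADME assay on microsomes from liver (Rattus norvegicus) for metabolic stability, with a stated time of 10 min; on this read-out lower numbers stand for a less stable compound and higher numbers for a more stable compound. Within the data shown here, its only measured neighbour, compound 2 `CC(=O)NCCS(=O)(=O)NC(=O)c1ccc(Nc2nc(NC3(c4ccc(Cl)cc4)CC3)nc(OCC(F)(F)F)n2)cc1`, gives 100%, and the step of a number 7 percentage points higher from compound 1 to compound 2 (within the scatter) lies within the scatter, so compound 1 stands alongside compound 2 rather than apart from it. Compound 3 `CN(C)S(=O)(=O)NC(=O)c1ccc(Nc2nc(NC3(c4ccc(Cl)cc4)CC3)nc(OCC(F)(F)F)n2)cc1` differs from compound 1 by dimethylamino in place of 2-(((tert-butyl)carbamoyl)amino)ethyl on a sulfonyl sulfur. Among the measured compounds shown here, no measured step touches the sulfonyl substituent; the one recorded change, at the carbonyl carbon, left the read-out unchanged. Compound 3 is therefore expected to show a step of a number 1 percentage points lower from compound 1 to compound 3 (within the scatter), no larger than the scatter. The estimated value of compound 3 is 92%, within 75% to 100%.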

Compound 3, percent of the compound remaining: 76%
Compound 3: the middle estimate sits 16 percentage points above what was measured; measured number inside the range.
By their numbers in this assay, from the lowest: compound 3; then compounds 1 and 2 (each within the scatter of the next).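

In this assay the sulfonyl sulfur proves a place that responds: dimethylamino in place of 2-(((tert-butyl)carbamoyl)amino)ethyl gives a number 17 percentage points lower from compound 1 to compound 3 (beyond the scatter) and dimethylamino in place of 2-acetamidoethyl gives a number 24 percentage points lower from compound 2 to compound 3 (beyond the scatter) at this position. Unlike the carbonyl carbon change, both steps lie beyond the scatter. Nothing available explains this difference. Going by these compounds, whether the dimethylamino group itself or the loss of the longer chain matters stays open, since the two change together. A morpholine or a short chain ending in a carboxylic acid on that sulfur would help separate them.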